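Adding One Chloro Group to an Inactive Compound

This account rests on a few compounds, and the source may have more. Where it says the series, first, only, none or still open, it means among the compounds named here.

This small set is made up of compound 1 (`O=C(CCCCC(S)CCS)Nc1ccccn1`), compound 2 (`O=C(CCCCC(S)CCS)Nc1ccc(Cl)cn1`), compound 3 (`O=C(CCCCC(CCSC(=O)c1ccccc1)SC(=O)c1ccccc1)Nc1ccccc1`) and compound 4 (`O=C(CCCCC(CCSC(=O)c1ccccc1)SC(=O)c1ccccc1)Nc1ccc(Cl)cc1`). All of them belong to a functional assay on Bel-7402 cells (Homo sapiens) for inhibition, read by MTT assay, with a stated time of 24 h, tested at 10 ug/mL (a lower number here means less inhibition of growth, a higher number more inhibition of growth at the concentration tested), and the first three already have results. Compound 1 is recorded as "not active" (no number reported) with no figure attached. Compound 2 reaches 17.8% and is the only one so far to give a number. Compound 3 is recorded as "not active" (no number reported) and so has no single number, which leaves it alongside compound 1 as the other entry without one.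

The move from compound 3 to compound 4 is chloro in place of hydrogen on an aromatic carbon and turns the phenyl into 4-chlorophenyl, para to a large group. Among the compounds with values here, no measured pair shows this same change directly, so the expectation is tentative. A small step towards more inhibition is expected in this assay and it may stay within the scatter. Within the data shown here, the only guide is compound 2, which also carries a chloro group and gives 17.8% as its reading. A report without any number would remain quite possible. Compound 4 is expected at an estimated 12% within a range of 0% to 28% when measured.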

Compound 4, percent growth inhibition at one concentration: 4.87%
For compound 4 the middle estimate is 7.1 percentage points above the measured one, and the stated range covers the measured number.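

In this assay compound 3 is recorded as "not active" (no number reported) and compound 4 gives 4.87% with no figure to set against it, so no step can be read between the two. The compounds shown leave open how far going from phenyl to 4-chlorophenyl shifts growth inhibition. No available evidence bears on this result.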